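This account rests on a few compounds, and the source may have more. Where it says the series, first, only, none or still open, it means among the compounds named here.

Measured in a functional assay on SGC-7901 cells (Homo sapiens) for inhibition, read by MTT assay, with a stated time of 24 h; on this read-out higher numbers stand for weaker inhibition and lower numbers for stronger inhibition:
compound 1 `Cc1ccccc1-n1cc(CN2C(=O)C[C@@H]3CC[C@@]2(C)C3(C)C)nn1` gives 350 nM
compound 2 `COc1ccccc1-n1cc(CN2C(=O)C[C@@H]3CC[C@@]2(C)C3(C)C)nn1` gives 280 nM
compound 3 `CC1(C)[C@H]2CC[C@]1(C)N(Cc1cn(-c3ccccc3Br)nn1)C(=O)C2` gives 500 nM

Compound 2 shows the lowest of the three numbers, with compound 1 nearest and compound 3 furthest, yet both steps from it lie within the scatter, so nothing separates the three. Compound 4 `CC1(C)[C@H]2CC[C@]1(C)N(Cc1cn(-c3cccc(C#N)c3)nn1)C(=O)C2` is not yet measured; its change from compound 2 is 3-cyanophenyl in place of 2-methoxyphenyl on an aromatic nitrogen. The measured steps each exchange one group on an aromatic carbon of that ring: a 1.3-fold lower number from compound 1 to compound 2 (0.10 log units; within the scatter), a 1.4-fold higher number from compound 1 to compound 3 (0.15 log units; within the scatter) and a 1.8-fold higher number from compound 2 to compound 3 (0.25 log units; within the scatter). None left the scatter. Among the compounds with values here, the new group and its placement have no measured counterpart, so no step beyond the scatter is expected in this assay; the expected step is a 1.4-fold higher number from compound 2 to compound 4 (0.13 log units; within the scatter). Compound 4 is estimated at 380 nM, range 150 nM to 950 nM.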

Compound 4, half-maximal inhibitory concentration: 250 nM
Compound 4: middle estimate off by 1.5-fold (0.18 log units), on the high side, and the stated range covers the measured number.
By their numbers in this assay, from the lowest: compounds 4, 2, 1 and 3 (each within the scatter of the next).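

In this assay 3-cyanophenyl on the aromatic nitrogen gives a 1.1-fold lower number from compound 2 to compound 4 (0.05 log units; within the scatter) and a 1.4-fold lower number from compound 1 to compound 4 (0.15 log units; within the scatter) and a 2.0-fold lower number from compound 3 to compound 4 (0.30 log units; within the scatter) and all three steps lie within the scatter. The earlier compounds shown here covered only 2-substituted phenyl groups; this result extends the flat picture to a nitrile-bearing ring with a different substitution pattern, and the four compounds remain unseparated. Nothing available bears on why these values stay together.

As far as these compounds go, whether 2-cyanophenyl would match 3-cyanophenyl remains open. So does whether an amine, a carboxylic acid or a longer chain on the phenyl ring would produce a step beyond the scatter.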